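The source may hold more compounds than are shown below. What is called first, only, known or untested is meant among the compounds shown, and "the series" means these compounds.

Measured so far:
compound 1, `COc1cc2c(Nc3cccc([N+](=O)[O-])c3)ncnc2c(OC)c1OC`, 39000 nM
compound 2, `COc1cc2c(Nc3ccc(Cl)cc3)ncnc2c(OC)c1OC`, 34400 nM

Two compounds share one core and differ only in the substituent carried by the amino-linked phenyl ring. In a functional assay on BGC-823 cells (Homo sapiens) for inhibition, read by MTT assay, with a stated time of 72 h (a higher number here means a weaker inhibitor, a lower number a stronger inhibitor), compound 1 gives 39000 nM, and compound 2 gives 34400 nM. Within the data shown here, compound 2 holds the lower of the two numbers, but its only neighbour, compound 1, lies within the scatter of it, so no order between the two can be read from these values.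

Compound 3, `COc1cc2c(Nc3ccc(Br)cc3)ncnc2c(OC)c1OC`, has not yet been measured. Relative to compound 2 the change is bromo in place of chloro on an aromatic carbon. Among the measured compounds shown here, no step between measured compounds covers this exchange, and the two measured values say nothing about one halogen against another at that place on the ring. With a single heavy atom swapped for a single heavy atom, no hydrogen-bond donors or acceptors gained or lost, and no charge involved, no step beyond the scatter is expected in this assay, in either direction. The estimated shift is a 1.1-fold lower number from compound 2 to compound 3 (0.03 log units; within the scatter). Compound 3 is therefore expected to come in near 32000 nM, with a range from 13000 nM to 80000 nM.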

Compound 3, half-maximal inhibitory concentration: 23800 nM
Beside the measured number, compound 3's estimate is 1.3-fold (0.13 log units) above it; the measured number falls inside the stated range.
By their numbers in this assay, from the lowest: compounds 3, 2 and 1 (each within the scatter of the next).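

Among these compounds, the exchange of chloro for bromo, read as 4-chlorophenyl to 4-bromophenyl, gives a 1.4-fold lower number from compound 2 to compound 3 (0.16 log units; within the scatter) in this assay and so supplies the first step between compounds that differ in one place. On an aromatic carbon para to a large group, the two halogens cannot be told apart in this assay, and one can stand in for the other without a step beyond the scatter. Nothing on hand bears on the reason for this result.

Going by these compounds, whether an amine, a carboxylic acid, a fluoro group or a longer chain at the same place on the ring would give a step beyond the scatter stays open, since the two halogens cover only a narrow part of what could stand there. The methoxy groups of the shared core are the same in all the compounds shown, so the effect of an exchange at those places in this assay is open as well.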